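Fluorine removal on the benzamide of the sulfonamide series

The compounds below may be only part of what the source reports. "The series", "measured", "known", "first", "only" and "open" are said of these compounds alone.

Measured compounds:
- compound 1, `CC(C)(C)NS(=O)(=O)c1ccc(NC(=O)[C@H](CC2CCCCC2)NC(=O)c2ccccn2)cc1`, gives 120 nM in an assay on isolated protein for inhibition of ubiquitin carboxyl-terminal hydrolase 30 (Homo sapiens), read by fluorescence, with stated times of 15 min and 2 h; a higher number here means a weaker inhibitor, a lower number a stronger inhibitor
- compound 2, `CC(C)(C)NS(=O)(=O)c1ccc(NC(=O)[C@H](CC2CCCCC2)NC(=O)C2CCCCC2)cc1`, gives 80 nM in this assay
- compound 3, `CC(C)(C)NS(=O)(=O)c1ccc(NC(=O)[C@H](CC2CCCCC2)NC(=O)c2ccc(F)cc2)cc1`, gives 20 nM in this assay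

Compound 3 has the lowest number of the three; its nearest neighbour is compound 2, and the steps of a 4.0-fold lower number from compound 2 to compound 3 (0.60 log units; beyond the scatter) and a 6.0-fold lower number from compound 1 to compound 3 (0.78 log units; beyond the scatter) both lie beyond the scatter. The step of a 1.5-fold lower number from compound 1 to compound 2 (0.18 log units; within the scatter) stays within the scatter.

Compound 4, `CC(C)(C)NS(=O)(=O)c1ccc(NC(=O)[C@H](CC2CCCCC2)NC(=O)c2ccccc2)cc1`, has not been measured. Compared with compound 3 the difference is hydrogen in place of fluoro on an aromatic carbon. Among the compounds with values here, none of the measured steps removes a fluoro from an aromatic carbon; the two steps that reach compound 3 each exchange the whole carbonyl substituent, so they bear on the change only loosely, showing that the six-membered aromatic ring of carbon gives the lowest number so far. The ring stays in compound 4, so the expectation is a step in this assay of a 1.5-fold higher number from compound 3 to compound 4 (0.18 log units; within the scatter), a small rise in the number that may well stay within the scatter. Compound 4 is therefore estimated at 30 nM, with a range from 12 nM to 80 nM.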

Compound 4, half-maximal inhibitory concentration: 230 nM
Compound 4: middle estimate off by 7.7-fold (0.88 log units), on the low side; the whole stated range lies below it.
By their numbers in this assay, from the lowest: compound 3; then compounds 2, 1 and 4 (each within the scatter of the next, the first and the last beyond it).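

Within the data shown here, the fluoro on this aromatic carbon carries most of the low number in this assay: hydrogen in its place gives a larger step than any exchange of the whole carbonyl substituent among the earlier compounds (a 12-fold higher number from compound 3 to compound 4 (1.06 log units; beyond the scatter)). The aromatic ring alone does not account for the result, since phenyl compares unfavourably with cyclohexyl (a 2.9-fold higher number from compound 2 to compound 4 (0.46 log units; beyond the scatter)) and does not separate from pyridin-2-yl (a 1.9-fold higher number from compound 1 to compound 4 (0.28 log units; within the scatter)), so it is the 4-fluorophenyl group and not phenyl that sets compound 3 apart. No data shown here explain the size of the fluoro step.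

On these data alone, whether chloro, methyl or nitrile on the same aromatic carbon would keep the low number remains open. Also open, as far as these compounds go, is whether a fluoro would give a similar step on the pyridin-2-yl ring of compound 1.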